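The source may report more compounds than this note shows. Statements on the series, on what has been measured and on what is new or still open speak of the compounds shown alone.

Values in a functional assay on SK-MEL-2 cells (Homo sapiens) for cytotoxicity; a lower number here means a stronger inhibitor, a higher number a weaker inhibitor:
- Compound 1 `Cc1ccc(C2CN(S(=O)(=O)c3ccccc3)C(=O)N2)cc1`: > 316000 nM
- Compound 2 `Cc1ccc(S(=O)(=O)N2CC(c3ccccc3)NC2=O)cc1`: 2530 nM

The entry for compound 1, > 316000 nM, is a limit of the assay and not a number. Within the data shown here, compound 2, at 2530 nM, therefore holds the only true number so far, and it is the natural starting point for comparison.

Compound 3 `Cc1ccc(C2CN(S(=O)(=O)c3ccc(C)cc3)C(=O)N2)cc1` differs from compound 2 in one place: methyl in place of hydrogen on an aromatic carbon. This puts methyl in place of hydrogen on an aromatic carbon, turning phenyl into 4-methylphenyl.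

Among the measured compounds shown here, no measured step shows what this change does in this assay, so the expectation rests on compound 2 at 2530 nM and on how small the change is. The expected result is a modest move toward weaker inhibition, an estimated 2.4-fold higher number from compound 2 to compound 3 (0.38 log units; beyond the scatter), though the direction is uncertain. For compound 3 the estimated value is 6000 nM, with an expected range of 800 nM to 60000 nM.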

Compound 3, half-maximal inhibitory concentration: > 302000 nM
Compound 3 was reported as a limit (the forecaster's own chance of this, stated with the estimate: 15%); at least 50-fold (1.70 log units) between middle value and limit.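

A single methyl in place of hydrogen, on an aromatic carbon para to a large group, turns phenyl into 4-methylphenyl and gives an at least 110-fold higher number from compound 2 to compound 3 (2.07 log units; beyond the scatter) in this assay. The entry for compound 3, > 302000 nM, is a limit of the assay and not a number. Among these compounds, this is the first view of what a change at this position does: compound 2, with hydrogen there, has a measurable value, and this one small addition is enough to lose it.

As far as these compounds go, compound 1 and compound 3 both carry limits, so the step between them cannot be read, and what a methyl does on the other aromatic ring stays open. Also open, from the compounds shown here alone, is how a group other than methyl at this position, such as fluorine, methoxy or an amine, would behave.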